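The compounds below may be only part of what the source reports. "The series", "measured", "known", "first", "only" and "open" are said of these compounds alone.

In an assay on HEK293 cells for displacement of a labelled ligand from 5-hydroxytryptamine receptor 7 (Rattus norvegicus) (a higher number here means a weaker inhibitor, a lower number a stronger inhibitor), the three compounds that have been measured span a wide range. Compound 1 `COc1ccccc1N1CCN(CC(=O)NC2CCCc3c(OC)cccc32)CC1` gives > 1000 nM, which is a limit of the assay rather than a number, so (the limit of > 1000 nM in this assay, at which 1 of the 3 values shown sits). Compound 2 `COc1ccc2c(c1)CCCC2NC(=O)CCCCCN1CCN(c2ccccc2OC)CC1` gives 30 nM. Compound 3 `O=C(CCCCCN1CCN(c2nc3ccccc3o2)CC1)NC1CCCc2ccccc21` gives 820 nM, the highest of the two numbers that are known; the nearest is compound 2, a gap that lies beyond the scatter.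

Compound 4 `CC(=O)c1ccc(N2CCN(CCCCCC(=O)NC3CCCc4ccccc43)CC2)cc1` has not yet been measured in this assay. It differs from compound 3 in one place: 4-acetylphenyl in place of 1,3-benzoxazol-2-yl on an amine nitrogen in a ring. No step between two measured compounds isolates this change, so the expectation for compound 4 rests on the whole of what is shown. With a six-carbon chain and an unsubstituted core like that of compound 3, and a phenyl group on the ring nitrogen as in compound 2, the step from compound 3 to compound 4 is expected to be modest and downward, a 2.7-fold lower number from compound 3 to compound 4 (0.44 log units; beyond the scatter), but it may well stay within the scatter. In this assay compound 4 is therefore estimated at 300 nM, with a plausible range from 50 nM to 1500 nM.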

Compound 4, inhibition constant: 2640 nM
Beside the measured number, compound 4's estimate is 8.8-fold (0.94 log units) below it; the measured number lies above the stated range.
By their numbers in this assay, from the lowest: compound 2; then compound 3; then compound 4.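

In this assay, going by these compounds alone, this is the first step that isolates one change, and it shows that the group on the amine nitrogen in the ring matters with the chain and the core held fixed: 4-acetylphenyl in place of 1,3-benzoxazol-2-yl gives a 3.2-fold higher number from compound 3 to compound 4 (0.51 log units; beyond the scatter). The step is modest but beyond the scatter, and the two groups are equal in their count of heavy atoms, so that count alone does not separate them; they differ instead in the rings and hetero atoms listed for each. No measurement shown accounts for the direction of this step.

Going by these compounds, it remains open whether the acetyl group or the loss of the five-membered aromatic ring with its hetero atoms goes with the higher number, and an unsubstituted phenyl on the same nitrogen, or a phenyl carrying an amine or a carboxylic acid in place of the acetyl, would bear on that. On these data alone, it is also open whether the step keeps its direction and size with a shorter or longer chain, or with a methoxy group on the core.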